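The source may hold more compounds than are shown below. What is called first, only, known or untested is meant among the compounds shown, and "the series" means these compounds.

Measured compounds:
- compound 1, `CC[C@@H](Nc1c(C#N)c(-c2ccc(-c3ccccc3F)cc2)nc2cnccc12)C(N)=O`: 2.7
- compound 2, `CCOc1ccccc1-c1ccc(-c2nc3cnccc3c(N[C@H](CC)C(=O)NS(C)(=O)=O)c2C#N)cc1`: 2.2
- compound 3, `CCCCC(Nc1c(C#N)c(-c2ccc(-c3ccccc3OCC)cc2)nc2cnccc12)C(N)=O`: 3.6

In a physicochemical assay for lipophilicity, read by HPLC, at pH 7.5 (a higher number here means a more lipophilic compound, a lower number a more polar compound), compound 1 stands second highest of the three numbers; the nearest is compound 2, which gives 2.2, and the furthest is compound 3, which gives 3.6. Among the measured compounds shown here, the only one-place step between measured compounds is a number 1.40 log units higher from compound 2 to compound 3 (beyond the scatter), a large change on the nitrogen on the aromatic ring.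

Compound 4, `CC[C@@H](Nc1c(C#N)c(-c2ccc(-c3cccc(CO)c3)cc2)nc2cnccc12)C(N)=O`, is not yet measured. It differs from compound 1 only on the aromatic carbon of the six-membered ring of carbon only, para to a large group: 3-(hydroxymethyl)phenyl in place of 2-fluorophenyl on an aromatic carbon

For the measured compounds named here, no measured step touches this ring, so the step from compound 2 to compound 3 bears on it only in showing that a one-group change can move this assay well beyond the scatter. The entering group carries one hydrogen-bond donor and one acceptor where the leaving group had none, so a downward step beyond the scatter is expected. For compound 4 the estimate is 1.8, in the range 1.3 to 2.3, which is expected to mean a step of a number 0.90 log units lower from compound 1 to compound 4 (beyond the scatter) from compound 1.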

Compound 4, distribution coefficient: 2
The estimate for compound 4 lay 0.20 log units below the measured number; low and high end bracket the measured number.
By their numbers in this assay, from the lowest: compounds 4 and 2 (each within the scatter of the next); then compound 1; then compound 3.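

In this assay, among the compounds shown here, 3-(hydroxymethyl)phenyl in place of 2-fluorophenyl, on an aromatic carbon para to a large group, gives a number 0.70 log units lower from compound 1 to compound 4 (beyond the scatter), so this position, which no earlier step touched, also moves the read-out. The entering group counts one hydrogen-bond donor and one hydrogen-bond acceptor where the leaving group counts none, and the number falls with that change in this single pair. Nothing available here accounts for the size of the step.

The pair changes the substituent and its place on the ring together, so the contribution of each stays unresolved. From the compounds shown here alone, what a 3-fluorophenyl group, or an aminomethyl group or a carboxylic acid in place of the hydroxymethyl, would give in this assay remains open.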